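Working notes on four compounds in a cytotoxicity assay

The source may report more compounds than this note shows. Statements on the series, on what has been measured and on what is new or still open speak of the compounds shown alone.

Measured so far:
compound 1 `COc1ccc(-n2nnnc2Nc2ccc(Cl)cc2)cc1`: 245000 nM
compound 2 `COc1ccc(Nc2nnnn2-c2cccc(Cl)c2)cc1`: 124000 nM
compound 3 `COc1ccc(-n2nnnc2Nc2ccc(F)cc2)cc1`: 236000 nM

In an ADME assay on V79 cells (Cricetulus griseus) for cytotoxicity, read by MTT assay, with a stated time of 72 h (on this read-out lower numbers stand for stronger inhibition and higher numbers for weaker inhibition), compound 1 gives 245000 nM and compound 3 gives 236000 nM. The two differ by fluoro in place of chloro on an aromatic carbon, and the step is a 1.0-fold lower number from compound 1 to compound 3 (0.02 log units; within the scatter). Compound 2 shares its atoms with compound 1 but has them joined differently; the difference between the two cores is not broken down here. In this assay compound 2 gives 124000 nM, and its gaps to compound 1 and to compound 3 both lie within the scatter, so no order among the three is read.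

Compound 4 `COc1ccc(Nc2nnnn2-c2cccc(F)c2)cc1` is not yet measured. It differs from compound 2 by fluoro in place of chloro on an aromatic carbon. For the measured compounds named here, this is the same kind of change as the one from compound 1 to compound 3, but the surroundings differ: in the measured pair the change sits para to a large group, whereas here it sits meta to a large group. Among the compounds shown the change occurs twice in all.

In this assay the step from compound 2 to compound 4 is expected to be a 1.0-fold higher number from compound 2 to compound 4 (0.00 log units; within the scatter), beside the measured one, because a 1.0-fold lower number from compound 1 to compound 3 (0.02 log units; within the scatter) was within the scatter. Compound 4 is therefore estimated at 125000 nM, with a likely range from 60000 nM to 260000 nM.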

Compound 4, half-maximal inhibitory concentration: 123000 nM
Estimate against measurement, compound 4: 1.0-fold (0.01 log units) above, within the range that was stated.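

In this assay, fluoro in place of chloro on the second core gives a 1.0-fold lower number from compound 2 to compound 4 (0.00 log units; within the scatter), and this step does not differ from the one on the first core: the same change on two cores in this assay, a 1.0-fold lower number (0.02 log units; within the scatter) from compound 1 to compound 3 and a 1.0-fold lower number (0.00 log units; within the scatter) from compound 2 to compound 4, 1.0-fold (0.01 log units) apart, within the scatter of two such steps

Within these two pairs, the change therefore carries from one core to the other as a step within the scatter, and the chloro and fluoro compounds on a given core cannot be told apart in this assay. For the compounds shown here, this is agreement between two steps that are both within the scatter, drawn from only two pairs in a single assay, so it does not show that a change with a step beyond the scatter would carry across these cores in the same way, and it does not extend to other changes or other read-outs. The two pairs also differ in where the change sits as well as in their cores, so the contribution of each cannot be separated here.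

The compounds shown carry only chloro or fluoro at the changed place, which leaves open whether an amine, a carboxylic acid or a nitrile there would give a step beyond the scatter on either core. On these data alone, all four compounds also keep the methoxy group, so what a hydroxy group or a longer alkoxy chain in its place would do remains open.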